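The compounds below may be only part of what the source reports. "The series", "measured", "known", "first", "only" and "open" are said of these compounds alone.

Measured so far:
- Compound 1 `CCN(CC)S(=O)(=O)c1ccc(S(=O)(=O)N2CCC[C@@H](C(=O)NC3CN(C(=O)OC(C)(C)C)C3)C2)cc1`: in a functional assay on MIA PaCa-2 cells (Homo sapiens) for inhibition, read by MTT assay, with a stated time of 7 days (a higher number here means a weaker inhibitor, a lower number a stronger inhibitor), compound 1 gives 200 nM.
- Compound 2 `CCN(CC)S(=O)(=O)c1ccc(S(=O)(=O)N2CCC[C@@H](C(=O)NC3CN(C(=O)NC(C)(C)C)C3)C2)cc1`: compound 2 gives 3400 nM.
- Compound 3 `CCN1CC(NC(=O)[C@@H]2CCCN(S(=O)(=O)c3ccc(S(=O)(=O)N(CC)CC)cc3)C2)C1`: compound 3 gives only a limit of this assay, > 30000 nM.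

Compound 3 thus stands at the bottom of the three values, with no number of its own, only (the limit of > 30000 nM in this assay, at which 1 of the 3 values shown sits). From compound 1 the change was an at least 150-fold higher number from compound 1 to compound 3 (2.17 log units; beyond the scatter), and from compound 2 an at least 8.8-fold higher number from compound 2 to compound 3 (0.94 log units; beyond the scatter); both steps remove a carbonyl-bearing substituent from the ring nitrogen and both are lost in this assay.

Compound 4 `CCN(CC)S(=O)(=O)c1ccc(S(=O)(=O)N2CCC[C@@H](C(=O)N[C@H]3CCN(C(=O)OC(C)(C)C)C3)C2)cc1` is the next step: 1-(tert-butoxycarbonyl)pyrrolidin-3-yl in place of 1-ethylazetidin-3-yl on an amide-type nitrogen. It restores the tert-butoxycarbonyl that compound 1 carries and enlarges the ring by one atom. The step from compound 1 to compound 3 is the one that bears on it, read in reverse, so a large gain is expected. Among the compounds with values here, no measured pair tells how the ring enlargement alone acts, so the estimate is set somewhat short of compound 1 and the range is kept wide. Compound 4 is expected to show an at least 60-fold lower number from compound 3 to compound 4 (1.77 log units; beyond the scatter), landing at 500 nM (range 120 nM to 3000 nM).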

Compound 4, half-maximal inhibitory concentration: 100 nM
The estimate for compound 4 lay 5.0-fold (0.70 log units) above the measured number; the measured number lies below the stated range.
By their numbers in this assay, from the lowest: compounds 4 and 1 (each within the scatter of the next); then compound 2. At a limit, above all of these: compound 3.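

In this assay, tert-butoxycarbonyl on the ring nitrogen carries over from the four-membered to the five-membered ring, with a 2.0-fold lower number from compound 1 to compound 4 (0.30 log units; within the scatter), so swapping 1-(tert-butoxycarbonyl)azetidin-3-yl for 1-(tert-butoxycarbonyl)pyrrolidin-3-yl on the amide-type nitrogen gives no readable difference. The gaps to the other two compounds remain large, with a 34-fold lower number from compound 2 to compound 4 (1.53 log units; beyond the scatter) and an at least 300-fold lower number from compound 3 to compound 4 (2.47 log units; beyond the scatter), although the 2>4 pair differs in both the ring and the carbonyl substituent, and the last step is only a bound. Compound 3 has a limit of the assay, not a number: the limit of > 30000 nM in this assay, at which 1 of the 4 values shown sits.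

Still open, on these data alone, is whether a benzyloxycarbonyl or acetyl group on the ring nitrogen could stand in for tert-butoxycarbonyl. Also open, as far as these compounds go, is how (tert-butyl)carbamoyl or ethyl would behave on the five-membered ring, and what the opposite configuration at its defined stereocentre would give.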